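This account rests on a few compounds, and the source may have more. Where it says the series, first, only, none or still open, it means among the compounds named here.

In a functional assay on A549 cells (Homo sapiens) for cytotoxicity, with a stated time of 48 h (a higher number here means a weaker inhibitor, a lower number a stronger inhibitor), compound 1 (`C[S+]([O-])/C=C/c1cc(=O)c2ccccc2o1`) gives 1900 nM and compound 2 (`COc1cccc2oc(/C=C/[S+](C)[O-])cc(=O)c12`) gives 3800 nM on the same read-out. Going by the values given here, compound 2 therefore stands within the scatter of compound 1, the only other number available. Compound 3 (`Cc1cccc2oc(/C=C/[S+](C)[O-])cc(=O)c12`) alters compound 2 at a single place, with methyl in place of methoxy on an aromatic carbon of the shared core. Among the compounds with values here, one measured step bears on that carbon, methoxy in place of hydrogen, and it is a 2.0-fold higher number from compound 1 to compound 2 (0.30 log units; within the scatter) for that exchange. Within the data shown here, no compound with methyl there has been measured. Neither hydrogen nor methoxy at that carbon separates the numbers, so no step beyond the scatter is expected in this assay for methyl. The estimated change is a 1.3-fold lower number from compound 2 to compound 3 (0.12 log units; within the scatter) and remains within the scatter. For compound 3 the expected value is 2900 nM with an estimated range of 1200 nM to 7000 nM in this measurement.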

Compound 3, half-maximal inhibitory concentration: 1300 nM
The estimate for compound 3 lay 2.2-fold (0.35 log units) above the measured number; the measured number falls inside the stated range.
By their numbers in this assay, from the lowest: compounds 3, 1 and 2 (each within the scatter of the next, the first and the last beyond it).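

In this assay, this aromatic carbon of the shared core now shows a step beyond the scatter, which the exchange of hydrogen for methoxy had not shown: methyl in place of methoxy gives a 2.9-fold lower number from compound 2 to compound 3 (0.47 log units; beyond the scatter) and is a modest change. Methyl in place of hydrogen gives a 1.5-fold lower number from compound 1 to compound 3 (0.16 log units; within the scatter) and stays within the scatter, so among the three groups only methoxy and methyl are told apart at this carbon, while hydrogen is separated from neither. Nothing available accounts for the step between methoxy and methyl.

The compounds shown leave open how an amine, a chlorine atom or a longer chain such as ethoxy would read at this carbon. They also leave open whether the step between methoxy and methyl would hold on any other carbon of the shared core.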